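A Cyano Group Replaces Nitro on the Benzyl Arm

The source may report more compounds than this note shows. Statements on the series, on what has been measured and on what is new or still open speak of the compounds shown alone.

Three measured compounds share one core and differ only in the substituted phenyl attached through a saturated chain carbon bound to an aromatic nitrogen. Compound 1 `O=c1ccoc2cc(OCc3cn(Cc4cccc(F)c4)nn3)ccc12` carries 3-fluorophenyl there; in a functional assay on QGY7701 cells (Homo sapiens) for cytotoxicity, read by MTT assay, with a stated time of 48 h (on this read-out higher numbers stand for weaker inhibition and lower numbers for stronger inhibition), compound 1 gives > 100000 nM, which is a limit of the assay rather than a number. Compound 2 `O=c1ccoc2cc(OCc3cn(Cc4ccccc4F)nn3)ccc12` carries 2-fluorophenyl, and in this assay compound 2 gives 36900 nM. The step is an at least 2.7-fold lower number from compound 1 to compound 2 (0.43 log units; beyond the scatter). Compound 3 `O=c1ccoc2cc(OCc3cn(Cc4ccc([N+](=O)[O-])cc4)nn3)ccc12` carries 4-nitrophenyl; in this assay compound 3 gives > 100000 nM, again a limit. Thus compound 3 stands at the limit of > 100000 nM in this assay, at which 2 of the 3 values shown sit. The step of an at least 2.7-fold higher number from compound 2 to compound 3 (0.43 log units; beyond the scatter) marks it as weaker than compound 2, while the comparison from compound 1 is a step that the two limits leave unreadable from compound 1 to compound 3.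

Compound 4 `N#Cc1ccc(Cn2cc(COc3ccc4c(=O)ccoc4c3)nn2)cc1` differs from compound 3 by cyano in place of nitro on an aromatic carbon. Among the measured compounds shown here, no measured step exchanges these two groups; the measured steps move the fluorine position or swap fluorophenyl for nitrophenyl. They show that changes on this phenyl can shift the number at least modestly, but give no direction for this change. The step expected a number no higher from compound 3 to compound 4 (the limit leaves the size open) is therefore none beyond the scatter. Compound 4 is expected to give about 100000 nM, with a range from 40000 nM to 300000 nM, and a real chance that only a limit is reported.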

Compound 4, half-maximal inhibitory concentration: > 100000 nM
Compound 4 was reported as a limit; the forecaster's own chance of this, stated with the estimate: 60%; the middle value sits exactly at the limit.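

In this assay, compound 4, with 4-cyanophenyl on the arm, stops at a limit of the assay rather than giving a number, so the limit now holds most of this small set: the limit of > 100000 nM in this assay, at which 3 of the 4 values shown sit.

Among the compounds shown here, the one readable comparison is an at least 2.7-fold higher number from compound 2 to compound 4 (0.43 log units; beyond the scatter), which places 4-cyanophenyl, like 4-nitrophenyl, on the weaker side of 2-fluorophenyl. The other steps among these compounds, including cyano in place of nitro, cannot be read, since both ends of each sit at the limit, so the exchange has no measurable size or direction here.

Among the compounds shown, only compound 2 gives a number, and it leaves open whether that number depends on having fluorine at that spot on the phenyl or on having any group there, which a 2-cyanophenyl or 2-nitrophenyl arm would address. Going by these compounds, it also remains open whether an amine or a carboxylic acid on this phenyl, or a longer chain between the phenyl and the aromatic nitrogen, would bring the value below the limit.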